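Hydroxy to nitro on the aryl piperazine of compound 1

The compounds below may be only part of what the source reports. "The series", "measured", "known", "first", "only" and "open" are said of these compounds alone.

The series shares a core carrying a substituted aryl piperazine. Compound 1 `Nc1nc(N)c2cc(CSC(=S)N3CCN(c4ccc(O)cc4)CC3)ccc2n1` bears a hydroxy on the aryl ring and, in a functional assay on HeLa cells (Homo sapiens) for antiproliferative activity, read by MTT assay, with a stated time of 72 h (a higher number here means a weaker inhibitor, a lower number a stronger inhibitor), compound 1 gives 5180 nM, the highest of the two numbers recorded. Compound 3 `Nc1nc(N)c2cc(CSC(=S)N3CCN(c4ccc(F)cc4)CC3)ccc2n1` carries fluoro in its place, and compound 3 gives 1840 nM; the step of a 2.8-fold lower number from compound 1 to compound 3 (0.45 log units; beyond the scatter) is the only measured one that bears on the change considered here. Compound 2 `Cc1ccccc1N1CCN(C(=S)SCc2ccc3nc(N)nc(N)c3c2)CC1`, with a methyl on the aryl ring, gives "not determined" (no result reported), so no number is available from it.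

Compound 4 `Nc1nc(N)c2cc(CSC(=S)N3CCN(c4ccc([N+](=O)[O-])cc4)CC3)ccc2n1` differs from compound 1 by nitro in place of hydroxy on an aromatic carbon. As with fluoro, the hydroxy group leaves. Given the modest fall of a 2.8-fold lower number from compound 1 to compound 3 (0.45 log units; beyond the scatter) on replacing the same group, a step of similar size and direction is expected, though the single step gives a thin basis and the range is kept wide. Compound 4 is therefore estimated at 2500 nM (range 900 nM to 7000 nM), a step of a 2.1-fold lower number from compound 1 to compound 4 (0.32 log units; beyond the scatter) that is expected rather than measured.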

Compound 4, half-maximal inhibitory concentration: 1660 nM
Compound 4: the middle estimate sits 1.5-fold (0.18 log units) above what was measured, and the stated range covers the measured number.
By their numbers in this assay, from the lowest: compounds 4 and 3 (each within the scatter of the next); then compound 1.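

In this assay, a second replacement of the hydroxy on this aromatic carbon, para to a large group, lowers the number as well (a 3.1-fold lower number from compound 1 to compound 4 (0.49 log units; beyond the scatter)), in the same direction as the earlier fluoro change (a 2.8-fold lower number from compound 1 to compound 3 (0.45 log units; beyond the scatter)). Among the three compounds with numbers, hydroxy therefore stands apart from both replacements, with no reversal, while nitro and fluoro cannot be told apart (a 1.1-fold lower number from compound 3 to compound 4 (0.04 log units; within the scatter)).

Going by these compounds, whether an amine, a carboxylic acid or a methoxy group at the same place would read with nitro and fluoro or with hydroxy remains open. No supporting evidence is available on what separates compound 1 from compound 3 and compound 4.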